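The source may hold more compounds than are shown below. What is called first, only, known or untested is meant among the compounds shown, and "the series" means these compounds.

Measured compounds in the series:
- compound 1, `FC(F)(F)c1ccc2[nH]c(-c3ccccc3)nc2c1` — 468000 nM
- compound 2, `CC(C)Oc1ccccc1-c1nc2cc([N+](=O)[O-])ccc2[nH]1` — 14100 nM
- compound 3, `COc1cc(-c2nc3cc([N+](=O)[O-])ccc3[nH]2)ccc1O` — 19500 nM

In a functional assay on aorta (Rattus norvegicus, strain Wistar) for inhibition, with a stated time of 60 min (a lower number here means that less compound is needed, a higher number that more compound is needed for the effect), compound 1 gives the highest of the three numbers; compound 3 and compound 2 both sit well below it, by margins beyond the usual scatter. Among the measured compounds shown here, no pair of measured compounds differs in one place only, so no single step is on record; compound 2 and compound 3 each differ from compound 1 at several positions at once.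

Compound 4, `CN(C)c1ccc(-c2nc3cc(C(F)(F)F)ccc3[nH]2)cc1`, is not yet measured. It differs from compound 1 as follows: dimethylamino in place of hydrogen on an aromatic carbon.

With the core of compound 1 kept, a step of modest size toward a lower number is expected, that is a 3.1-fold lower number from compound 1 to compound 4 (0.49 log units; beyond the scatter). For compound 4 the estimate in this assay is 150000 nM, within a range of 40000 nM to 500000 nM.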

Compound 4, half-maximal effective concentration: 550000 nM
Compound 4: middle estimate off by 3.7-fold (0.56 log units), on the low side, and the stated range ends below it.
By their numbers in this assay, from the lowest: compounds 2 and 3 (each within the scatter of the next); then compounds 1 and 4 (each within the scatter of the next).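

In this assay, among the compounds shown here, dimethylamino in place of hydrogen on an aromatic carbon, para to a large group, gives a 1.2-fold higher number from compound 1 to compound 4 (0.07 log units; within the scatter) and provides the first single-place step. On the core of compound 1, hydrogen and dimethylamino at this position therefore cannot be told apart in this measurement. No accompanying measurement bears on this result.

As far as these compounds go, whether a carboxylic acid, a methoxy group or a longer chain at this position would also leave the number unchanged remains open. Equally open, from the compounds shown here alone, is what separates compound 2 and compound 3 from compound 1, as they differ from it at several positions at once.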